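This account rests on a few compounds, and the source may have more. Where it says the series, first, only, none or still open, it means among the compounds named here.

In a functional assay on MCF7 cells (Homo sapiens) for inhibition, read by sulforhodamine B assay, with a stated time of 72 h (a lower number here means a stronger inhibitor of growth, a higher number a weaker inhibitor of growth), compound 1 `NNC(=O)CCc1ccncc1-c1ccc2ccccc2c1` gives > 10000 nM, which is a limit and not a number. Compound 2 `O=C(CCc1ccncc1-c1ccc2ccccc2c1)N1CCOCC1` gives > 10000 nM, again a limit. Between them lies a step that the two limits leave unreadable from compound 1 to compound 2, which sets no size. For compound 1 the only reference is thus (the limit of > 10000 nM in this assay, at which 2 of the 3 values shown sit). For the measured compounds named here, compound 3 `CCOC(=O)/C=C/c1ccncc1-c1ccc2c(ccn2C)c1` gives 8670 nM, the only actual number so far. Compound 4 `COC(=O)/C=C/c1ccncc1-c1ccc2ccccc2c1` alters the chain of compound 1: 2-(methoxycarbonyl)ethenyl in place of 2-(aminocarbamoyl)ethyl on an aromatic carbon. Going by the values given here, no measured step covers this change. Among the compounds with values here, the sole guide is compound 3 at 8670 nM, which also bears an ester on an ethenyl chain, though on another core. A modest step toward stronger growth inhibition is therefore expected, and the estimated step is an at least 1.4-fold lower number from compound 1 to compound 4 (0.15 log units; that floor lies within the scatter). For compound 4 the expected value is 7000 nM, with an estimated range from 2500 nM to 18000 nM.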

Compound 4, concentration for 50% growth inhibition: 8170 nM
The estimate for compound 4 lay 1.2-fold (0.07 log units) below the measured number; low and high end bracket the measured number.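

In this assay, 2-(methoxycarbonyl)ethenyl in place of 2-(aminocarbamoyl)ethyl on this aromatic carbon, opposite the ring nitrogen, gives an at least 1.2-fold lower number from compound 1 to compound 4 (0.08 log units; that floor lies within the scatter). For the compounds shown here, on the core of compound 1, compound 4 is the first compound with a readable number, 8170 nM, so a change in this one place is enough to give one. The step stays a floor only because compound 1 carries a limit and not a number: the limit of > 10000 nM in this assay, at which 2 of the 4 values shown sit.

The change swaps the link and the end group together, so the compounds shown do not separate the ethenyl link from the methyl ester. As far as these compounds go, how a 2-(methoxycarbonyl)ethyl chain, a carboxylic acid or a longer chain would read at this position stays open.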